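Swapping the aromatic group on a cytotoxicity series

This account rests on a few compounds, and the source may have more. Where it says the series, first, only, none or still open, it means among the compounds named here.

- Compound 1 `Cc1ccc(CNc2nc3ccc([N+](=O)[O-])cc3nc2NCCCN(C)C)cc1` gives 15.8 ug/mL
- Compound 2 `CN(C)CCCNc1nc2cc([N+](=O)[O-])ccc2nc1NCc1ccccc1Br` gives 51.9 ug/mL
- Compound 3 `COc1ccccc1CNc1nc2ccc([N+](=O)[O-])cc2nc1NCCCN(C)C` gives 36.1 ug/mL

In an ADME assay on HEK293 cells (Homo sapiens) for cytotoxicity, read by MTT assay, with a stated time of 24 h (on this read-out lower numbers stand for stronger inhibition and higher numbers for weaker inhibition), compound 3 gives 36.1 ug/mL, which is level with compound 2 within the scatter and higher than compound 1. Compound 4 `CN(C)CCCNc1nc2cc([N+](=O)[O-])ccc2nc1NCc1cc(F)cc(C(F)(F)F)c1` changes one group: 3-fluoro-5-(trifluoromethyl)phenyl in place of 2-methoxyphenyl on a saturated chain carbon bound to a nitrogen on an aromatic ring. Three measured swaps of this aromatic group bear on it: a 3.3-fold higher number from compound 1 to compound 2 (0.52 log units; beyond the scatter), a 2.3-fold higher number from compound 1 to compound 3 (0.36 log units; beyond the scatter) and a 1.4-fold lower number from compound 2 to compound 3 (0.16 log units; within the scatter). These steps range from within the scatter to modest. For the measured compounds named here, no measured compound carries fluorine, so the direction stays open and only a small step is expected. The expected change is a 1.2-fold lower number from compound 3 to compound 4 (0.08 log units; within the scatter). For compound 4 the estimated value is 30 ug/mL, with an expected range from 12 ug/mL to 75 ug/mL.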

Compound 4, half-maximal inhibitory concentration: 2.67 ug/mL
The estimate for compound 4 lay 11-fold (1.05 log units) above the measured number; the whole stated range lies above it.
By their numbers in this assay, from the lowest: compound 4; then compound 1; then compounds 3 and 2 (each within the scatter of the next).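

In this assay, placing 3-fluoro-5-(trifluoromethyl)phenyl on this saturated chain carbon gives a 14-fold lower number from compound 3 to compound 4 (1.13 log units; beyond the scatter) and a 19-fold lower number from compound 2 to compound 4 (1.29 log units; beyond the scatter) and a 5.9-fold lower number from compound 1 to compound 4 (0.77 log units; beyond the scatter) as the result of this single swap. This makes compound 4 the strongest inhibitor of the four, and it shows that this position can shift the number much further than the earlier swaps did. Nothing available explains why the number falls so far.

As far as these compounds go, it remains open whether the fluorine or the trifluoromethyl group drives the drop. A phenyl ring carrying only one of them could separate the two.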